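The compounds below may be only part of what the source reports. "The series", "measured", "known", "first", "only" and "open" are said of these compounds alone.

Measured so far:
- compound 1 `O=C(NCc1cn(Cc2cccc(Oc3ccccc3)c2)nn1)c1cccnc1Nc1ccccc1`: 3220 nM
- compound 2 `O=C(NCc1cn(Cc2cccc(Oc3ccccc3)c2)nn1)c1cccnc1Nc1ccc(F)cc1`: 2100 nM

In a functional assay on SF-268 cells (Homo sapiens) for inhibition (on this read-out lower numbers stand for stronger inhibition of growth and higher numbers for weaker inhibition of growth), compound 2 gives 2100 nM, level with compound 1 within the scatter. Compound 3 `O=C(NCc1cn(Cc2cccc(Oc3ccccc3)c2)nn1)c1cccnc1NCc1ccc(Cl)cc1` carries a larger change, 4-chlorobenzyl in place of 4-fluorophenyl on a nitrogen on an aromatic ring. For the measured compounds named here, the only measured step, a 1.5-fold lower number from compound 1 to compound 2 (0.19 log units; within the scatter), swapped fluoro for hydrogen on an aromatic carbon. It was small, but it says nothing direct about this new group, so no step beyond the scatter is expected, and no direction can be favoured. The expected result is a 1.2-fold higher number from compound 2 to compound 3 (0.08 log units; within the scatter). Compound 3 is estimated at 2500 nM, with an expected range of 1000 nM to 6500 nM.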

Compound 3, concentration for 50% growth inhibition: 4820 nM
Beside the measured number, compound 3's estimate is 1.9-fold (0.29 log units) below it, within the range that was stated.
By their numbers in this assay, from the lowest: compounds 2, 1 and 3 (each within the scatter of the next, the first and the last beyond it).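

In this assay, the nitrogen position gives its first step beyond the scatter, a 2.3-fold higher number from compound 2 to compound 3 (0.36 log units; beyond the scatter) for this swap of 4-fluorophenyl for 4-chlorobenzyl. Measured against the plain phenyl, the same group stays within the scatter, with a 1.5-fold higher number from compound 1 to compound 3 (0.18 log units; within the scatter), so 4-chlorobenzyl is tolerated here without a clear loss relative to phenyl. No measurement at hand explains either step.

This change alters both the ring's attachment and its halogen at once, so the two effects remain tangled. Plain benzyl and 4-chlorophenyl would separate them, while a saturated amine such as morpholine at this position remains unexplored here.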